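The source may hold more compounds than are shown below. What is called first, only, known or untested is meant among the compounds shown, and "the series" means these compounds.

Compound 1 `Cc1cc(C)n(-c2ccc(S(=O)(=O)NC(=O)NC3CCCCC3)cc2)n1` is the reference point of this account. In a functional assay on the whole organism (blood, strain albino) with Mus musculus as the target, with stated times of 6 days and 4 h, at a dose of 0.4 mmol/kg by the oral route (a higher number here means more inhibition at the dose given (going by the name of the read-out), a lower number less inhibition), compound 1 gives 10% as its read-out. Of the other two measured compounds, compound 2 `Cc1cc(C(=O)O)nn1-c1ccc(S(=O)(=O)NC(=O)NC2CCCCC2)cc1` gives 1% in the same assay, a value within the scatter of compound 1, while compound 3 `Cc1cc(C)n(-c2ccc(S(=O)(=O)NC(=S)Nc3ccccc3)cc2)n1` gives -3% there, a gap to compound 1 that lies beyond the scatter. Among the measured compounds shown here, the only single-change step recorded is a number 9 percentage points lower from compound 1 to compound 2 (within the scatter) and it comes with carboxy in place of methyl on an aromatic carbon. For the measured compounds named here, no single-change step connects compound 3 to either of the others.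

Compound 4 `CCCNC(=O)NS(=O)(=O)c1ccc(-n2nc(C)cc2C)cc1` has not yet been measured. It differs from compound 1 in one place: propyl in place of cyclohexyl on an amide-type nitrogen describes the change. Going by the values given here, no recorded step touches the amide-type nitrogen, so nothing measured bears directly on this exchange. Among the compounds with values here, the one step that is known, a number 9 percentage points lower from compound 1 to compound 2 (within the scatter) at a different position, stayed within the scatter, and all three measured numbers sit low on the percentage scale. On that basis compound 4 is expected to remain close to compound 1, and the step of a number 4 percentage points lower from compound 1 to compound 4 (within the scatter) is the expected outcome. Compound 4 is accordingly estimated at 6% with a range from -8% to 20% in this assay.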

Compound 4, a percentage reported as inhibition, in the whole organism at one dose (the size of the read-out at that dose, not a potency): < 1%
Compound 4: only a limit was reported; the forecaster's own chance of this, stated with the estimate: 2%; at least 5 percentage points between middle value and limit.
By their numbers in this assay, from the lowest: compounds 3, 2 and 1 (each within the scatter of the next, the first and the last beyond it).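

Among the compounds shown here, the propyl in place of cyclohexyl exchange is the first recorded change on the amide-type nitrogen, and in this assay it reads as a number at least 9 percentage points lower from compound 1 to compound 4 (that floor lies within the scatter). For compound 4 the reported < 1% is a limit of the assay and not a number. The exchange therefore shows that this position, unlike the aromatic carbon of the earlier step, has now been probed, and that swapping the cyclohexyl ring for the open propyl chain does not lift the read-out over that of compound 1, while the true size of the drop stays unknown and is bounded from one side only: the limit of < 1% in this assay, at which 1 of the 4 values shown sits.

The compounds shown leave open whether any group on this nitrogen could move the read-out beyond the scatter of compound 1 in either direction, for instance a longer chain such as hexyl, or a smaller ring such as cyclopentyl. They also leave open how far down compound 4 truly lies, and whether a carboxylic acid on the aromatic carbon would read the same alongside propyl as it does alongside cyclohexyl.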